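This account rests on a few compounds, and the source may have more. Where it says the series, first, only, none or still open, it means among the compounds named here.

Measured so far:
compound 1, `Fc1ccccc1Cc1nc(-c2nc(C(F)(F)F)n[nH]2)n2ccccc12`: 6 10^-6 cm/s
compound 2, `FC(F)(F)c1n[nH]c(-c2nc(Cc3cncnc3)c3ccccn23)n1`: 19 10^-6 cm/s

Both numbers come from an ADME assay on MDCKII-LE cells (Canis lupus familiaris) for permeability, in the apical to basolateral direction; on this read-out higher numbers stand for higher permeability and lower numbers for lower permeability. For the measured compounds named here, compound 1 gives the lowest of the two numbers; the only other compound, compound 2, gives a 3.2-fold higher number from compound 1 to compound 2 (0.50 log units; beyond the scatter), a step that comes from putting pyrimidin-5-yl in place of 2-fluorophenyl on a saturated chain carbon bound to an aromatic carbon.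

The step followed here goes from compound 1 to compound 3, `Fc1ccccc1Cc1nc(-c2nc(Cc3ccccc3)n[nH]2)n2ccccc12`. The change is benzyl in place of trifluoromethyl on an aromatic carbon. Going by the values given here, the benzyl sits on an aromatic carbon of a five-membered aromatic ring with 3 nitrogen, between two ring nitrogen atoms, so it is a different place from the one changed between compound 1 and compound 2, and the group that leaves and the group that enters are both different as well. Among the compounds with values here, no measured step therefore bears directly on this change. With nothing to lean on, the expectation for this assay is a 1.3-fold higher number from compound 1 to compound 3 (0.12 log units; within the scatter), a step not expected to go beyond the scatter in either direction. Compound 3 is estimated at 8 10^-6 cm/s, with a range from 3 10^-6 cm/s to 20 10^-6 cm/s.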

Compound 3, apparent permeability: 0.5 10^-6 cm/s
Estimate against measurement, compound 3: 16-fold (1.20 log units) above; measured number outside the range, below it.
By their numbers in this assay, from the lowest: compound 3; then compound 1; then compound 2.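

In this assay, the position on an aromatic carbon of a five-membered aromatic ring with 3 nitrogen, between two ring nitrogen atoms, proves highly sensitive to what it carries: benzyl in place of trifluoromethyl gives a 12-fold lower number from compound 1 to compound 3 (1.08 log units; beyond the scatter). For the compounds shown here, the earlier step, a 3.2-fold higher number from compound 1 to compound 2 (0.50 log units; beyond the scatter), was at a different place and went the other way, so this is the first sign that a single change to the compound 1 structure can also lower the number, and by a large step. The two groups match in their counts of hydrogen-bond donors, hydrogen-bond acceptors and net charge, differing instead in heavy atoms, atom types and the six-membered aromatic ring that benzyl brings, and no measurement here accounts for the step.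

As far as these compounds go, with only one replacement at this position, it remains open whether the ring, the number of heavy atoms or the loss of the fluorine atoms goes with the lower number. A methyl, a longer carbon chain without a ring, or an amine at the same position would help separate these possibilities.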